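Swapping an aminopyrazine for a hydroxyquinoline on a shared core

The source may hold more compounds than are shown below. What is called first, only, known or untested is meant among the compounds shown, and "the series" means these compounds.

Compound 1 `Cc1nc2c3ccccc3ccc2c2nc3c(ccc4ccccc43)c(-c3cccc([N+](=O)[O-])c3)c12`: 157 ug/mL
Compound 2 `Cc1nc2c3ccccc3ccc2c2nc3c(ccc4ccccc43)c(-c3nccnc3N)c12`: 134 ug/mL
Compound 3 `Cc1nc2c3ccccc3ccc2c2nc3c(ccc4ccccc43)c(-c3ccc(O)cc3)c12`: 99 ug/mL

These three compounds share one core and differ only in the group on one aromatic carbon; all were tested in a functional assay, with a stated time of 90 s; on this read-out lower numbers stand for stronger inhibition and higher numbers for weaker inhibition. Compound 2 cannot be separated from either neighbour, since the step of a 1.2-fold lower number from compound 1 to compound 2 (0.07 log units; within the scatter) and the step of a 1.4-fold lower number from compound 2 to compound 3 (0.13 log units; within the scatter) both lie within the scatter, as does a 1.6-fold lower number from compound 1 to compound 3 (0.20 log units; within the scatter). Compound 4 `Cc1nc2c3ccccc3ccc2c2nc3c(ccc4ccccc43)c(-c3cc(O)nc4ccccc34)c12` carries the change (2-hydroxyquinolin-4-yl in place of 3-aminopyrazin-2-yl on an aromatic carbon). Within the data shown here, no measured step involves this group, and the three swaps seen so far all left the number essentially unchanged, so no step beyond the scatter is expected, a 1.1-fold lower number from compound 2 to compound 4 (0.03 log units; within the scatter). Compound 4 is therefore estimated at 125 ug/mL, within 60 ug/mL to 260 ug/mL.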

Compound 4, half-maximal inhibitory concentration: 148 ug/mL
Beside the measured number, compound 4's estimate is 1.2-fold (0.07 log units) below it; measured number inside the range.
By their numbers in this assay, from the lowest: compounds 3, 2, 4 and 1 (each within the scatter of the next).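

Putting a second aromatic ring on this carbon, as 2-hydroxyquinolin-4-yl in place of 3-aminopyrazin-2-yl, gives a 1.1-fold higher number from compound 2 to compound 4 (0.04 log units; within the scatter) in this assay. The other two comparisons, a 1.5-fold higher number from compound 3 to compound 4 (0.17 log units; within the scatter) and a 1.1-fold lower number from compound 1 to compound 4 (0.03 log units; within the scatter), also stay within the scatter, so even this larger group leaves the four compounds indistinguishable. Nothing available explains this flat result.

As far as these compounds go, whether any group at this position can move the number beyond the scatter remains open. A carboxylic acid or an amine on a longer chain would be a very different kind of group to compare.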